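A Thiophene Sulfonamide Analogue Awaiting Measurement

A few compounds are considered here, and "the series" means these few. Any claim that something is new, unique, unknown or untested is made for them only; others in the source may bear on it.

compound 1 `O=S(=O)(Nc1ccc2oc(-c3ccccc3)nc2c1)c1cccc(C(F)(F)F)c1`: > 63000 nM
compound 2 `COc1cccc(S(=O)(=O)Nc2ccc3oc(-c4ccccc4)nc3c2)c1`: > 63000 nM
compound 3 `O=S(=O)(Nc1ccc(-c2nc3ccccc3o2)cc1)c1cccs1`: > 63000 nM

All three were tested in an assay on isolated protein for inhibition of malate dehydrogenase, mitochondrial (Sus scrofa), with stated times of 45 min and 30 min; on this read-out lower numbers stand for stronger inhibition and higher numbers for weaker inhibition. Compound 1 reaches only a limit of the assay, > 63000 nM. Compound 2 likewise gives only a limit, > 63000 nM. Compound 3 also stops at a limit, > 63000 nM. Taken together this is the limit of > 63000 nM in this assay, at which 3 of the 3 values shown sit. Among the compounds with values here, the only single-place step, from compound 1 to compound 2, is a step that the two limits leave unreadable from compound 1 to compound 2: methoxy in place of trifluoromethyl on an aromatic carbon produces no readable change. Compound 2 therefore stands at the limit, with no number beneath it.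

Compound 4 `O=S(=O)(Nc1ccc2oc(-c3ccccc3)nc2c1)c1cccs1` differs from compound 2 in one place: thiophen-2-yl in place of 3-methoxyphenyl on a sulfonyl sulfur. Within the data shown here, compound 3 carries the same thiophen-2-yl group on its sulfonyl sulfur but differs from compound 2 in more than one place, so no single step joins them. Among the measured compounds shown here, with the one measured step unreadable and every result at the limit, the expected step in this assay is a step that the limit leaves unreadable from compound 2 to compound 4, meaning no change beyond the scatter. Compound 4 is thus expected at 100000 nM, within 30000 nM to 300000 nM, most probably again reported only as a limit.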

Compound 4, half-maximal inhibitory concentration: > 63000 nM
Compound 4: a limit, no number; the forecaster's own chance of this, stated with the estimate: 85%; the middle value lies beyond the limit too.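

Compound 4 gives > 63000 nM, which is a limit of the assay and not a number. Compound 2 also stops at a limit, so the step between compound 2 and compound 4 cannot be read. The compounds shown leave open which change, if any, would give a measurable value in this assay: the limit of > 63000 nM in this assay, at which 4 of the 4 values shown sit.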